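The source may report more compounds than this note shows. Statements on the series, on what has been measured and on what is new or still open speak of the compounds shown alone.

Of the compounds shown here, three sharing one core have been measured in an assay on HeLa cells for displacement of a labelled ligand from 5-hydroxytryptamine receptor 6 (Homo sapiens); a lower number here means a stronger inhibitor, a higher number a weaker inhibitor. Compound 1 `Cc1c(S(=O)(=O)c2ccccc2)c2cccnc2n1CCN(C)C` gives 4.7 nM, and compound 2 `NCCn1cc(S(=O)(=O)c2cccc(F)c2)c2cccnc21` gives 4.7 nM. Compound 3 `O=S(=O)(c1cccc(F)c1)c1cn(CCN2CCCC2)c2ncccc12` gives 88 nM. Going by the values given here, the only step that joins two measured compounds differing in one place, a 19-fold higher number from compound 2 to compound 3 (1.27 log units; beyond the scatter), is large. Among the three numbers compound 3 stands highest, the weakest inhibitor of the set, with compound 1 and compound 2 both a long way below it.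

Compound 4 `O=S(=O)(c1cccc(Cl)c1)c1cn(CCN2CCCC2)c2ncccc12` is the next compound and differs from compound 3 in a single place: chloro in place of fluoro on an aromatic carbon. Among the compounds with values here, no measured step bears on this change; the one step known, from compound 2 to compound 3, alters the chain end and leaves the halogen untouched. A swap of one halogen for another on the same ring carbon therefore has no precedent among these compounds, and for compound 4 a step of the size a 1.1-fold lower number from compound 3 to compound 4 (0.04 log units; within the scatter) is expected in this assay, which is none beyond the scatter. For compound 4 the estimate in this assay is 80 nM, within a range from 25 nM to 250 nM.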

Compound 4, inhibition constant: 45 nM
The estimate for compound 4 lay 1.8-fold (0.25 log units) above the measured number; low and high end bracket the measured number.
By their numbers in this assay, from the lowest: compounds 1 and 2 (each within the scatter of the next); then compounds 4 and 3 (each within the scatter of the next).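

In this assay, the step of a 2.0-fold lower number from compound 3 to compound 4 (0.29 log units; within the scatter) lies within the scatter, so at this aromatic carbon the 3-fluorophenyl and 3-chlorophenyl compounds cannot be told apart. Going by these compounds alone, this is the first look at this ring position, and in this pair, exchanging one halogen for the other leaves no measurable mark, unlike the change at the chain end, a 19-fold higher number from compound 2 to compound 3 (1.27 log units; beyond the scatter), which lies beyond the scatter. Nothing measured here offers an explanation for this result.

On these data alone, it remains open whether a larger or different group on the same ring carbon, such as methoxy, trifluoromethyl or nitrile, would also stay within the scatter. As far as these compounds go, it is also open whether chloro in place of fluoro would behave the same way with amino rather than pyrrolidin-1-yl at the chain end.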